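Moving a fluorine around a phenyl ring

This account rests on a few compounds, and the source may have more. Where it says the series, first, only, none or still open, it means among the compounds named here.

Measured so far:
Compound 1, `Cc1cc(COc2ccc(Cl)cc2)nc(-c2ccccn2)n1`: 251 nM
Compound 2, `COc1ccc(OCc2cc(C)nc(-c3ccccn3)n2)cc1`: 7940 nM
Compound 3, `Cc1cc(COc2ccccc2F)nc(-c2ccccn2)n1`: 398 nM

All three were tested in a functional assay on cells for antagonist activity at Free fatty acid receptor 1 (Homo sapiens), read by TR-FRET and inositol phosphate accumulation, with a stated time of 2 h; on this read-out lower numbers stand for stronger inhibition and higher numbers for weaker inhibition. Compound 3 sits next to compound 1, the two within the scatter of each other, and far from compound 2, whose number is beyond the scatter above both. The step of a 1.6-fold higher number from compound 1 to compound 3 (0.20 log units; within the scatter) shows that swapping one halogen-bearing phenyl for another left the number essentially where it was, whereas a 32-fold higher number from compound 1 to compound 2 (1.50 log units; beyond the scatter) shows that putting a methoxy where the chloro was raised it sharply.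

Compound 4, `Cc1cc(COc2ccc(F)cc2)nc(-c2ccccn2)n1`, is not yet measured. It differs from compound 3 by 4-fluorophenyl in place of 2-fluorophenyl on an oxygen on a saturated carbon; the same atoms are simply joined differently. Within the data shown here, no measured step moves a fluorine from one position of this phenyl to another. The closest guide is compound 1, where a chloro occupies the same position the fluorine takes here and where the number stands close to that of compound 3. The step of a 1.3-fold lower number from compound 3 to compound 4 (0.12 log units; within the scatter) is therefore expected to stay within the scatter, in no clear direction. Compound 4 is estimated at 300 nM, with a range from 120 nM to 800 nM.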

Compound 4, half-maximal inhibitory concentration: 631 nM
For compound 4 the middle estimate is 2.1-fold (0.32 log units) below the measured one; the measured number falls inside the stated range.
By their numbers in this assay, from the lowest: compounds 1, 3 and 4 (each within the scatter of the next, the first and the last beyond it); then compound 2.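

In this assay the fluorine's move from 2-fluorophenyl to 4-fluorophenyl gives a 1.6-fold higher number from compound 3 to compound 4 (0.20 log units; within the scatter) and so cannot be told apart from the scatter, which means these two placements give no clear difference. With the group held in one place, the halogen swap gives a 2.5-fold higher number from compound 1 to compound 4 (0.40 log units; beyond the scatter) and stands as a modest step beyond the scatter, so fluoro and chloro are not fully interchangeable here, though compound 3 lies within the scatter of both compound 1 and compound 4. Methoxy still stands well apart, as a 13-fold lower number from compound 2 to compound 4 (1.10 log units; beyond the scatter) shows, and no measurement at hand explains any of these differences.

As far as these compounds go, it remains open whether a chloro would behave like the fluorine when moved around this phenyl. From the compounds shown here alone, it is also open whether a nitrile, an amine or a carboxylic acid on that aromatic carbon would fall with the halogens or with methoxy.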